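The source may report more compounds than this note shows. Statements on the series, on what has been measured and on what is new or still open speak of the compounds shown alone.

Working notes on the aryl sulfone series.

Three compounds have numbers in an assay on isolated protein for displacement of a labelled ligand from metabotropic glutamate receptor 5 (Homo sapiens), with a stated time of 60 min, tested at 1 uM; a lower number here means less inhibition, a higher number more inhibition at the concentration tested (going by the name of the read-out). Compound 1, `CC1CCN(c2c(S(=O)(=O)c3ccc(Cl)cc3)cnc3cc(Cl)ccc23)CC1`, gives 91% in this assay. Compound 2, `COc1ccc(S(=O)(=O)c2cnc3ccc(F)cc3c2N2CCC(C)CC2)cc1`, gives 85%. Compound 3, `CC1CCN(c2c(S(=O)(=O)c3cc(F)cc(F)c3)cnc3cc(F)ccc23)CC1`, gives 77%. On these three numbers compound 2 sits between the other two, but the gap to compound 1 and the gap to compound 3 both lie within the usual scatter of this assay, so no order among the three can be read from them. Among the measured compounds shown here, no pair of the measured compounds differs in only one place, so no single structural step has a measured size here.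

Compound 4, `Cc1ccc(S(=O)(=O)c2cnc3ccc(F)cc3c2N2CCC(C)CC2)cc1F`, is not yet measured. It differs from compound 2 as follows: 3-fluoro-4-methylphenyl in place of 4-methoxyphenyl on a sulfonyl sulfur. The three measured compounds carry three different aryl groups on the sulfonyl sulfur and all return high inhibition within the scatter of each other, so a further change at that position is expected to move the number little; the step from compound 2 to compound 4 in this assay is estimated at a number 1 percentage points lower from compound 2 to compound 4 (within the scatter), not beyond the scatter. Compound 4 is therefore expected to give about 84% in this assay, with a range from 70% to 94%.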

Compound 4, a percentage reported as inhibition, at one concentration (the size of the read-out at that concentration, not a potency): 86%
For compound 4 the middle estimate is 2 percentage points below the measured one, and the stated range covers the measured number.
By their numbers in this assay, from the lowest: compounds 3, 2, 4 and 1 (each within the scatter of the next, the first and the last beyond it).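

In this assay, among the compounds shown here, the exchange of 4-methoxyphenyl for 3-fluoro-4-methylphenyl on a sulfonyl sulfur gives a number 1 percentage points higher from compound 2 to compound 4 (within the scatter) and is the first change at this position with the rest of the structure held constant. The earlier compounds shown here differed in more than one place, so only now can this position be read alone: here, the hydrogen-bond acceptor counted on the leaving group is absent from the entering group, and the size of the step stays within the scatter. No measurement shown here bears on why the step has this size.

As far as these compounds go, whether an aryl group carrying an amine or a carboxylic acid on the sulfonyl sulfur would stay within the scatter remains open. Readings at a single concentration also leave any difference in potency between these compounds open.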